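The source may report more compounds than this note shows. Statements on the series, on what has been measured and on what is new or still open speak of the compounds shown alone.

Measured so far:
Compound 1, `COc1cc2c(Oc3ccc(NC(=O)c4nn(-c5ccccc5OC(F)(F)F)c(=O)cc4C)cc3F)ccnc2cc1OCCCN1CCC(C)CC1`, gives 250 nM in a functional assay on HT-29 cells (Homo sapiens) for inhibition, read by MTT assay, with a stated time of 72 h; a lower number here means a stronger inhibitor, a higher number a weaker inhibitor.
Compound 2, `COc1cc2c(Oc3ccc(NC(=O)c4nn(-c5cccc(F)c5)c(=O)cc4C)cc3F)ccnc2cc1OCCCN1CCCCC1`, gives 290 nM in this assay.

Among the measured compounds shown here, only two compounds have been measured, and no step between them is drawn, since they differ in more than one place. What their two values show is that compound 2 and compound 1 lie within the scatter of each other; nothing separates them beyond the noise of repeated measurement.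

Compound 3, `COc1cc2c(Oc3ccc(NC(=O)c4nn(-c5cccc(F)c5)c(=O)cc4C)cc3F)ccnc2cc1OCCCN1CCC(C)CC1`, has not yet been measured. It differs from compound 2 in one place: methyl in place of hydrogen on a saturated ring carbon. For the measured compounds named here, no measured pair isolates this change. Compound 1 already carries the 4-methylpiperidin-1-yl group, though on a different aryl partner, and its value of 250 nM sits within the scatter of compound 2, so the methyl gives no sign of shifting the number.

Compound 3 is therefore expected to show a step from compound 2 of a 1.1-fold lower number from compound 2 to compound 3 (0.03 log units; within the scatter), none beyond the scatter. The estimated value for compound 3 is 270 nM, within a range from 130 nM to 560 nM.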

Compound 3, half-maximal inhibitory concentration: 300 nM
Compound 3: the middle estimate sits 1.1-fold (0.05 log units) below what was measured; the measured number falls inside the stated range.
By their numbers in this assay, from the lowest: compounds 1, 2 and 3 (each within the scatter of the next).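

In this assay, among the compounds shown here, the change of methyl in place of hydrogen on a saturated ring carbon, three ring bonds from the ring nitrogen, is now isolated for the first time and gives a 1.0-fold higher number from compound 2 to compound 3 (0.01 log units; within the scatter) with everything else held fixed, so piperidin-1-yl and 4-methylpiperidin-1-yl cannot be told apart in this setting. Compound 3 also links compound 1 to the series through a single change, since 3-fluorophenyl in place of 2-(trifluoromethoxy)phenyl on an aromatic nitrogen gives a 1.2-fold higher number from compound 1 to compound 3 (0.08 log units; within the scatter) with the 4-methylpiperidin-1-yl group kept, and these two aryl groups cannot be separated here either. Nothing measured alongside these numbers offers an explanation for either result.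

The compounds shown leave open whether this ring carbon would read the same with something other than methyl on it, such as a hydroxyl, a primary amine, a carboxylic acid or a longer chain like ethyl. They also leave open whether morpholine in place of the piperidine ring, or an unsubstituted phenyl on the aromatic nitrogen, would stay level with these three compounds.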